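Trading a Cyanoethyl Chain for a Bromophenyl Ring

A few compounds are considered here, and "the series" means these few. Any claim that something is new, unique, unknown or untested is made for them only; others in the source may bear on it.

In a functional assay on MGC-803 cells (Homo sapiens) for inhibition, read by MTT assay, with a stated time of 72 h (a lower number here means a stronger inhibitor, a higher number a weaker inhibitor), compound 1 `C#CCSc1nc(NCCC#N)c2ccncc2n1` gives > 80000 nM as a limit and not a number. Compound 4 `C#CCSc1nc(Nc2ccc(Br)cc2)c2ccncc2n1` keeps the same core, and its change 4-bromophenyl in place of 2-cyanoethyl on a nitrogen on an aromatic ring puts 4-bromophenyl in place of 2-cyanoethyl on a nitrogen on an aromatic ring. Compound 2 `C#CCSc1nc(Nc2ccc(F)cc2)c2ccncc2n1` with 4-fluorophenyl gives 15800 nM in this assay on the same core. Compound 3 `C#CCSc1nc(Nc2ccccc2Cl)c2ccncc2n1` with 2-chlorophenyl gives 27600 nM there. Both replace the same chain, and the steps of an at least 5.0-fold lower number from compound 1 to compound 2 (0.70 log units; beyond the scatter) and an at least 2.8-fold lower number from compound 1 to compound 3 (0.46 log units; beyond the scatter) start from that limit, so they are minimum sizes. Only a 1.7-fold higher number from compound 2 to compound 3 (0.24 log units; within the scatter) separates those two rings. A similar drop is therefore expected, with an at least 5.0-fold lower number from compound 1 to compound 4 (0.69 log units; beyond the scatter) as the estimate. In this assay the estimated value for compound 4 is 16000 nM with 6000 nM to 45000 nM as its expected range.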

Compound 4, half-maximal inhibitory concentration: 26000 nM
The estimate for compound 4 lay 1.6-fold (0.21 log units) below the measured number, and the stated range covers the measured number.
By their numbers in this assay, from the lowest: compounds 2, 4 and 3 (each within the scatter of the next). At a limit, above all of these: compound 1.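

In this assay, 4-bromophenyl on this nitrogen also gives an at least 3.0-fold lower number from compound 1 to compound 4 (0.48 log units; beyond the scatter), so all three phenyl rings shown beat the 2-cyanoethyl chain. That size is only a minimum because compound 1 stands at a limit: the limit of > 80000 nM in this assay, at which 1 of the 4 values shown sits. Among the rings, both a 1.1-fold lower number from compound 3 to compound 4 (0.03 log units; within the scatter) and a 1.6-fold higher number from compound 2 to compound 4 (0.22 log units; within the scatter) stay within the scatter, so neither swap gives a readable difference.

From the compounds shown here alone, whether an amine or a carboxylic acid on the phenyl ring would shift the number stays open. So does whether a saturated cyclohexyl ring would serve as well as a phenyl ring.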